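A stereocentre flip at a ring carbon in a cytotoxic lactone series

The source may hold more compounds than are shown below. What is called first, only, known or untested is meant among the compounds shown, and "the series" means these compounds.

Measured so far:
compound 1, `CC(=O)O[C@H]1C[C@H](C)[C@H]2C[C@H]2C2=C(COC2=O)[C@H]1[C@H](C)CCC=C(C)C`: > 10 ug/mL
compound 2, `CC(=O)O[C@@H]1C(=O)C2C1CC/C=C(\C)CC[C@@H]2[C@H](C)CCC=C(C)C`: 5.4 ug/mL

The study followed cytotoxicity in a functional assay on NSCLC-N6 cells (Homo sapiens) for cytotoxicity; on this read-out higher numbers stand for an effect only at larger amounts of compound and lower numbers for an effect already at smaller amounts. Two compounds have numbers. Compound 1, with the structure `CC(=O)O[C@H]1C[C@H](C)[C@H]2C[C@H]2C2=C(COC2=O)[C@H]1[C@H](C)CCC=C(C)C`, gives only a limit in this assay, > 10 ug/mL, and so carries no exact number. Compound 2, with the structure `CC(=O)O[C@@H]1C(=O)C2C1CC/C=C(\C)CC[C@@H]2[C@H](C)CCC=C(C)C`, gives 5.4 ug/mL in this assay, and it is the only finite value among the two shown. Of the two values, one sits at the limit of > 10 ug/mL in this assay, at which 1 of the 2 values shown sits.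

The piece now turns to compound 3, with the structure `CC(=O)O[C@H]1C(=O)C2C1CC/C=C(\C)CC[C@@H]2[C@H](C)CCC=C(C)C`, which has not been measured. The change from compound 2 to compound 3 is the two compounds have the same atoms and bonds; at least one stereo element is drawn with a configuration in one of them and without one in the other: 1 of 6 stereo elements differ; a stereocentre at a saturated ring carbon is drawn S in compound 2 and R in compound 3. Among the measured compounds shown here, no measured pair in this set differs in one place, so no step size is known from the data. Since only the drawn configuration at one ring carbon changes, compound 3 is expected to stay close to compound 2, with a step of a 1.1-fold higher number from compound 2 to compound 3 (0.05 log units; within the scatter) in this assay, either direction possible. Compound 3 is therefore estimated at 6 ug/mL, with a range from 2 ug/mL to 20 ug/mL.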

Compound 3, concentration for half-maximal effect: 6.82 ug/mL
Beside the measured number, compound 3's estimate is 1.1-fold (0.06 log units) below it; low and high end bracket the measured number.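

The result gives this set its first step read at a single place, and in this assay that step is a 1.3-fold higher number from compound 2 to compound 3 (0.10 log units; within the scatter). Among the compounds shown here, as drawn, the change from S to R at this saturated ring carbon therefore leaves the two read-outs within the usual scatter of each other, something the earlier compounds could not show, as they differ in more than one place. This reading of the stereocentre is still only tentative, because the comparison does not set two fully defined configurations against each other: the fact that one of compounds 2 and 3 is drawn with a defined configuration and the other without, at the place where they differ

On these data alone, compound 1 remains a limit and not a number, so it offers no exact value for the series: the limit of > 10 ug/mL in this assay, at which 1 of the 3 values shown sits. Also open is what a hydroxyl group or an amine at this same ring carbon would do in this assay, and whether either would respond to the drawn configuration there any more than compound 2 and compound 3 do.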